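Aryl urea series: replacing the aryl with hydrazide

The compounds below may be only part of what the source reports. "The series", "measured", "known", "first", "only" and "open" are said of these compounds alone.

Three compounds share a common core and differ only at the far end of the urea. Compound 1 `COc1cc(NC(C)CCCNC(=O)NCCNC(c2ccccc2)(c2ccccc2)c2ccccc2)c2ncccc2c1` carries a trityl-amine extension and in a functional assay on HeLa cells (Homo sapiens) for inhibition, read by MTT assay, with a stated time of 4 days (on this read-out lower numbers stand for stronger inhibition and higher numbers for weaker inhibition), compound 1 gives 38000 nM. Compound 2 `COc1cc(NC(C)CCCNC(=O)NNC(=O)N(CCO)CCO)c2ncccc2c1` ends in a bis(2-hydroxyethyl)carbamoyl semicarbazide; in this assay compound 2 reaches only a limit, > 250000 nM, which is the limit noted as the limit of > 250000 nM in this assay, at which 1 of the 3 values shown sits. Compound 3 `COc1cc(NC(C)CCCNC(=O)Nc2ccc(Cl)c(C(F)(F)F)c2)c2ncccc2c1` has the 4-chloro-3-(trifluoromethyl)phenyl urea and in this assay compound 3 gives 3900 nM, the lowest of the two numbers recorded; compound 1 sits clearly higher. For the measured compounds named here, the one directly comparable step is an at least 64-fold lower number from compound 2 to compound 3 (1.80 log units; beyond the scatter), so the aryl end of the urea accounts for a large gain against the semicarbazide.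

Compound 4 `COc1cc(NC(C)CCCNC(=O)NN)c2ncccc2c1` is the next member: amino in place of 4-chloro-3-(trifluoromethyl)phenyl on an amide-type nitrogen. This step reverses much of what separated compound 2 from compound 3, leaving a short hydrazide in place of the aryl group. Going by the values given here, the change from compound 2 to compound 3 was the only measured step that bears on it, and it was large; a move of similar size in the opposite direction is therefore expected, though the limit reached by compound 2 leaves its full extent uncertain. Compound 4 is estimated at 100000 nM, with a range of 20000 nM to 250000 nM, corresponding to an expected step of a 26-fold higher number from compound 3 to compound 4 (1.41 log units; beyond the scatter).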

Compound 4, half-maximal inhibitory concentration: >= 250000 nM
Compound 4: only a limit was reported; the forecaster's own chance of this, stated with the estimate: 35%; middle value at least 2.5-fold (0.39 log units) from the limit.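

Amino in place of 4-chloro-3-(trifluoromethyl)phenyl on the amide-type nitrogen gives an at least 64-fold higher number from compound 3 to compound 4 (1.80 log units; beyond the scatter) in this assay, so this aryl group now stands apart from two different non-aryl ends at this place: the short hydrazide of compound 4 as well as the longer semicarbazide of compound 2. Compound 4 reaches only a limit of the assay, not a number: the limit of >= 250000 nM in this assay, at which 1 of the 4 values shown sits.
Compound 2 is also only a limit, and the step from it to compound 4, which removes bis(2-hydroxyethyl)carbamoyl, cannot be read: the limit of > 250000 nM in this assay, at which 1 of the 4 values shown sits.

The shown compounds do not separate the contribution of the six-membered aromatic ring from that of its chloro and trifluoromethyl substituents, a question that an unsubstituted phenyl or a 4-chlorophenyl on the same nitrogen would address. Also open, from the compounds shown here alone, is whether any non-aryl end can give a measurable number in this assay, for instance a cyclohexyl group or a longer alkyl chain carrying an amine, and how far the true value of compound 4 lies past its limit.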